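Thienopyrimidine series: piperazinyl substitution on the core

A few compounds are considered here, and "the series" means these few. Any claim that something is new, unique, unknown or untested is made for them only; others in the source may bear on it.

Measured compounds:
compound 1, `FC(F)(F)c1ccc(Nc2ncnc3sc(Nc4c(Cl)cccc4Cl)nc23)cc1`, 12 nM
compound 2, `Cc1cccc(C)c1Nc1nc2c(Nc3ccc(C(F)(F)F)cc3)ncnc2s1`, 23 nM
compound 3, `O=C(O)c1ccc(Nc2ncnc3sc(Nc4c(Cl)cccc4Cl)nc23)cc1`, a limit of > 5000 nM

In a functional assay on HEK293 cells for antagonist activity at transient receptor potential cation channel subfamily V member 1 (Homo sapiens), read by calcium flux (on this read-out higher numbers stand for weaker inhibition and lower numbers for stronger inhibition), compound 1 gives the lowest of the two numbers reported; the nearest is compound 2, with a 1.9-fold higher number from compound 1 to compound 2 (0.28 log units; within the scatter). Compound 3 sits at the limit of this assay, (the limit of > 5000 nM in this assay, at which 1 of the 3 values shown sits). The step of an at least 410-fold higher number from compound 1 to compound 3 (2.61 log units; beyond the scatter) shows that exchanging the trifluoromethyl for a carboxy group is not tolerated, while the step of a 1.9-fold higher number from compound 1 to compound 2 (0.28 log units; within the scatter) shows that the 2,6-disubstituted phenyl on the ring nitrogen may be varied without effect beyond the scatter.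

Compound 4, `FC(F)(F)c1ccc(Nc2nc(N3CCNCC3)nc3sc(Nc4c(Cl)cccc4Cl)nc23)cc1`, differs from compound 1 by piperazin-1-yl in place of hydrogen on an aromatic carbon. Neither measured step touches this position of the core, so neither bears directly on it; both modify the peripheral aryl groups. The substituent enters between two ring nitrogen atoms, meta to the (4-(trifluoromethyl)phenyl)amino group. Without a comparable step, the expectation is a modest weakening at most, expected as a 3.3-fold higher number from compound 1 to compound 4 (0.52 log units; beyond the scatter). Compound 4 is estimated at 40 nM, with a range of 8 nM to 300 nM.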

Compound 4, half-maximal inhibitory concentration: 5000 nM
The estimate for compound 4 lay 130-fold (2.10 log units) below the measured number, and the stated range ends below it.
By their numbers in this assay, from the lowest: compounds 1 and 2 (each within the scatter of the next); then compound 4.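

For the compounds shown here, the aromatic carbon between two ring nitrogen atoms, untouched by the earlier steps, does not accept piperazin-1-yl: in this assay this change gives a 420-fold higher number from compound 1 to compound 4 (2.62 log units; beyond the scatter). Going by these compounds alone, the earlier steps reached only the peripheral aryl groups, so this single example is the first sign that substitution on the core itself can cost as much as the loss of trifluoromethyl on the periphery. Within the data shown here, compound 3 alone carries a limit, and the figure in that limit is the one compound 4 reaches: the limit of > 5000 nM in this assay, at which 1 of the 4 values shown sits.

Going by these compounds, whether the loss belongs to piperazin-1-yl specifically or to any substituent on this carbon remains open. A methyl, a dimethylamino or a morpholine at this carbon, or an acetyl on the free piperazine nitrogen, would separate these readings.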